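The compounds below may be only part of what the source reports. "The series", "measured", "known", "first", "only" and "open" are said of these compounds alone.

Measured so far in a functional assay (Sus scrofa) with sulfonylurea receptors; K-ATP channels (Homo sapiens) as the target; a higher number here means a larger maximal response, a lower number a smaller maximal response:

Compound 1, `CC(=O)Nc1c(C(O)(C(F)(F)F)C(F)(F)F)ccc2ccccc12`, gives 87%.
Compound 2, `CCC(=O)Nc1c(C(O)(C(F)(F)F)C(F)(F)F)ccc2ccccc12`, gives 96%.

Compound 2 and compound 1 share one core and differ only in the chain on the amide side. The step of a number 9 percentage points higher from compound 1 to compound 2 (within the scatter) lies within the usual scatter, so the two values cannot be told apart with confidence; compound 2 has the higher number, but only by a margin that repeated measurement might erase.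

Compound 3, `CCCC(=O)Nc1c(C(O)(C(F)(F)F)C(F)(F)F)ccc2ccccc12`, carries this same kind of change one bond further along the chain: methyl in place of hydrogen on a saturated chain carbon, two bonds along the chain from a carbonyl carbon. Put differently, the ethyl becomes a propyl, the propanoyl a propylcarbonyl.

Among the compounds with values here, the one measured step that bears on this is the step from compound 1 to compound 2, where the chain also grew by one methyl, and that step was within the scatter. A second methyl on the same chain, placed one bond further out, is therefore expected to leave the maximal response where it is, with no step beyond the scatter in either direction: the estimated step is a number 2 percentage points lower from compound 2 to compound 3 (within the scatter).

Compound 3 is estimated at 94%, with a likely range from 80% to 106%.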

Compound 3, largest response reached (reported as efficacy), in percent of the reference or control that the assay uses: 92%
Beside the measured number, compound 3's estimate is 2 percentage points above it; the measured number falls inside the stated range.
By their numbers in this assay, from the lowest: compounds 1, 3 and 2 (each within the scatter of the next).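

In this assay, within the data shown here, adding a methyl on the saturated chain carbon, two bonds along the chain from a carbonyl carbon, gives a number 4 percentage points lower from compound 2 to compound 3 (within the scatter) and so produces no step that can be told from the scatter. This shows that the second position along the chain, like the first, has not moved the maximal response measurably. Read as one larger change, ethyl in place of hydrogen on the saturated chain carbon bound to a carbonyl carbon gives a number 5 percentage points higher from compound 1 to compound 3 (within the scatter) and is also too small to separate the compounds, and no measurement shown here accounts for this flat result.

A longer chain such as pentyl, a branched chain such as isopropyl, a ring such as cyclopropyl or phenyl, or an amine at the end of the chain might still produce a step beyond the scatter, and the compounds shown leave that open. They also leave open how much of each compound is needed to reach its largest response, as the read-out records only the size of that response.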